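The source may hold more compounds than are shown below. What is called first, only, known or untested is meant among the compounds shown, and "the series" means these compounds.

Working notes on a small set of compounds built on one shared core. Compound 1 `Cc1ccc(Nc2nnc(-c3ccc(C)cc3C)s2)cc1` and compound 2 `COc1cc(OC)cc(-c2nnc(Nc3ccc(Cl)c(Cl)c3)s2)c1` have been measured in an assay on isolated protein for inhibition of beta-glucuronidase (Bos taurus), read by spectrophotometry, with a stated time of 30 min; a lower number here means a stronger inhibitor, a higher number a weaker inhibitor. In this assay compound 1 gives 34300 nM, and compound 2 gives 19200 nM in this assay. Compound 1 has the higher of the two numbers, but the gap to compound 2 lies within the scatter, so no difference between the two can be claimed. Among the compounds with values here, no pair of measured compounds differs in a single place, so no step of known size is available within the set.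

Compound 3 `Cc1ccc(-c2nnc(Nc3cccc(Br)c3)s2)c(C)c1` has not yet been measured in this assay. Relative to compound 1 it carries 3-bromophenyl in place of 4-methylphenyl on a nitrogen on an aromatic ring. Within the data shown here, with no comparable step known, the expectation rests on the two measured values alone, which sit close together. The step in this assay is expected to be small, a 1.6-fold lower number from compound 1 to compound 3 (0.19 log units; within the scatter), leaning toward a lower number but not beyond the scatter. For compound 3 in this assay the estimate is 22000 nM, with a range from 7000 nM to 70000 nM.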

Compound 3, half-maximal inhibitory concentration: 36100 nM
Compound 3: the middle estimate sits 1.6-fold (0.22 log units) below what was measured; the measured number falls inside the stated range.
By their numbers in this assay, from the lowest: compounds 2, 1 and 3 (each within the scatter of the next).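

In this assay, within the data shown here, 3-bromophenyl in place of 4-methylphenyl on a nitrogen on an aromatic ring gives a 1.1-fold higher number from compound 1 to compound 3 (0.02 log units; within the scatter), so no difference between the two compounds can be claimed, and this is the first step of known size in the set. At this position, the exchange of one group of 7 heavy atoms and one six-membered aromatic ring of carbon only for another with the same counts leaves the two measured numbers indistinguishable, although carbon-only 4-methylphenyl gives way to a bromine-bearing group. Among these compounds, no supporting measurement is available to explain why this step is so small, and the single exchange does not show whether the bromine or its place on the ring has any effect of its own.

The compounds shown leave open whether this position stays as unresponsive with a group of another kind, such as a phenyl ring carrying a carboxylic acid or an amine, or a longer chain in place of the ring. Compound 2 differs from compound 1 and compound 3 in more than one place, so the contribution of its 3,4-dichlorophenyl-bearing nitrogen and its other aryl group cannot be separated.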